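A few compounds are considered here, and "the series" means these few. Any claim that something is new, unique, unknown or untested is made for them only; others in the source may bear on it.

The measured compounds and their values in a functional assay on HCT-116 cells (Homo sapiens) for cytotoxicity, read by MTT assay, with a stated time of 72 h; on this read-out lower numbers stand for stronger inhibition and higher numbers for weaker inhibition:

compound 1 `CN(C)CCCCCn1c2c(c3ccccc31)C(=O)c1c[n+]([O-])c3ccccc3c1C2=O`: 470 nM
compound 2 `O=C1c2c[n+]([O-])c3ccccc3c2C(=O)c2c1c1ccccc1n2CCCCn1ccnc1`: 240 nM
compound 3 `O=C1c2c[n+]([O-])c3ccccc3c2C(=O)c2c1c1ccccc1n2CCN1CCCC1`: 270 nM

Among these three, compound 2 has the lowest number, but its gaps to the other two are small: the step of a 1.1-fold higher number from compound 2 to compound 3 (0.05 log units; within the scatter) and the step of a 2.0-fold lower number from compound 1 to compound 2 (0.29 log units; within the scatter) both fall within the usual scatter of this assay, so on these numbers alone no compound can be called more active than another.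

Compound 4 `O=C1c2c[n+]([O-])c3ccccc3c2C(=O)c2c1c1ccccc1n2CCN1CCCCC1` has not yet been measured. It differs from compound 2 in one place: piperidin-1-yl in place of 2-(1H-imidazol-1-yl)ethyl on a saturated chain carbon, two bonds along the chain from an aromatic nitrogen. The measured step that bears most directly on this change is a 1.1-fold higher number from compound 2 to compound 3 (0.05 log units; within the scatter), where pyrrolidin-1-yl took the place of the same 2-(1H-imidazol-1-yl)ethyl group at the same position and the number hardly moved. The step of a 1.7-fold lower number from compound 1 to compound 3 (0.24 log units; within the scatter) also ended at the pyrrolidin-1-yl compound and stayed within the scatter. So far, swapping the group on the chain has not moved the number beyond the scatter for any of the three compounds. The step expected here is therefore a 1.3-fold higher number from compound 2 to compound 4 (0.10 log units; within the scatter), that is, nothing beyond the scatter. Compound 4 is expected to give about 300 nM, in the range 150 nM to 600 nM.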

Compound 4, half-maximal inhibitory concentration: 780 nM
For compound 4 the middle estimate is 2.6-fold (0.41 log units) below the measured one, and the stated range ends below it.
By their numbers in this assay, from the lowest: compounds 2, 3, 1 and 4 (each within the scatter of the next, the first and the last beyond it).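

In this assay, among the compounds shown here, the group on this chain is no longer freely interchangeable, as the earlier compounds suggested: with piperidin-1-yl in place of pyrrolidin-1-yl at the same place, the step is a 2.9-fold higher number from compound 3 to compound 4 (0.46 log units; beyond the scatter) and goes beyond the scatter, so a change of one saturated ring for another is enough to matter here. The change from the imidazole side chain, which leaves 4-(1H-imidazol-1-yl)butyl and brings in 2-(piperidin-1-yl)ethyl, gives a 3.3-fold higher number from compound 2 to compound 4 (0.51 log units; beyond the scatter) and also goes beyond the scatter, while the comparison with the dimethylamino side chain gives a 1.7-fold higher number from compound 1 to compound 4 (0.22 log units; within the scatter) and stays within it, so these two compounds cannot be told apart. Nothing shown here explains why these steps differ in size.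

As far as these compounds go, the step between compound 2 and compound 4 changes chain length and end group together, so it remains open which of the two matters; a piperidin-1-yl on a longer chain would separate them. From the compounds shown here alone, it also remains open whether a morpholin-4-yl or azepan-1-yl ring on the same chain would stay with compound 3 or with compound 4.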